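This account rests on a few compounds, and the source may have more. Where it says the series, first, only, none or still open, it means among the compounds named here.

Compound 2, `COc1ccc(Cn2cc(CO/N=C/c3c(-c4ccc(C)cc4)nc4ccc(Br)cn34)nn2)cc1`, gives 40 mg/kg in a functional assay on the whole organism (strain NMRI) with Mus musculus as the target, with a stated time of 4 h; a lower number here means that less compound is needed, a higher number that more compound is needed for the effect.
Compound 1, `Cc1ccc(Cn2cc(CO/N=C/c3c(-c4ccc(F)cc4)nc4ccc(Br)cn34)nn2)cc1`, gives 100 mg/kg in this assay.

Going by the values given here, of the two numbers measured so far, compound 2 has the lower one, and the gap to compound 1 lies beyond the usual scatter of this assay. The two compounds differ from each other in two places at once, so no single change can be tied to that gap; the values simply show that compound 2 needs less.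

Compound 3, `Cc1ccc(Cn2cc(CO/N=C/c3c(-c4ccc(C)cc4)nc4ccc(Br)cn34)nn2)cc1`, has not been measured yet. It differs from compound 2 in one place only: methyl in place of methoxy on an aromatic carbon. Among the compounds with values here, no measured pair shows this change on its own, so there is nothing to lean on. A small step is expected, of the size a 1.5-fold higher number from compound 2 to compound 3 (0.18 log units; within the scatter), and it could go either way. For compound 3 the estimate in this assay is 60 mg/kg, within a range from 25 mg/kg to 150 mg/kg.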

Compound 3, minimum effective dose: 100 mg/kg
Compound 3: middle estimate off by 1.7-fold (0.22 log units), on the low side; the range from low to high includes it.
By their numbers in this assay, from the lowest: compound 2; then compounds 1 and 3 (each within the scatter of the next).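

Going from 4-methoxybenzyl to 4-methylbenzyl gives a 2.5-fold higher number from compound 2 to compound 3 (0.40 log units; beyond the scatter) in this assay, so this position does affect the dose needed, and here the methoxy group is the one that needs less. The other single change, methyl in place of fluoro on an aromatic carbon, gives no change at the digits printed from compound 1 to compound 3 (within the scatter), so of the two exchanges only the methoxy one moves the number beyond the scatter. Nothing measured here speaks to the reason for this step.

As far as these compounds go, each exchange is read only once and in one setting, so it remains open whether the methoxy step would hold with fluoro in place of the methyl on the other ring. From the compounds shown here alone, it is also open how an amine, a hydroxyl or a longer chain such as ethoxy would compare at the position that carries the methoxy group.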